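The source may report more compounds than this note shows. Statements on the series, on what has been measured and on what is new or still open speak of the compounds shown alone.

Measured in a functional assay on thoracic aorta (Rattus norvegicus) for inhibition; a higher number here means that more compound is needed for the effect, a lower number that less compound is needed:
compound 1 `CC1(C)CC(NC(=O)Nc2cccc(C#N)c2)c2cc(NS(C)(=O)=O)ccc2O1` gives 9300 nM.
compound 2 `CC1(C)CC(NC(=O)Nc2cccc(Cl)c2)c2cc(NS(C)(=O)=O)ccc2O1` gives 15200 nM.
compound 3 `CC1(C)CC(NC(=O)Nc2ccc(Cl)cc2)c2cc(NS(C)(=O)=O)ccc2O1` gives > 30000 nM, which is a limit of the assay rather than a number.

Compound 1 holds the lowest of the two numbers; its nearest neighbour is compound 2, with a 1.6-fold higher number from compound 1 to compound 2 (0.21 log units; within the scatter). Compound 4 `CCS(=O)(=O)Nc1ccc2c(c1)C(NC(=O)Nc1cccc(C#N)c1)CC(C)(C)O2` differs from compound 1 by methyl in place of hydrogen on a saturated chain carbon bound to a sulfonyl sulfur. Among the compounds with values here, none of the measured steps touches that part of the molecule: an at least 3.2-fold higher number from compound 1 to compound 3 (0.50 log units; beyond the scatter) and an at least 1.9-fold higher number from compound 2 to compound 3 (0.29 log units; that floor lies within the scatter) both concern the aryl group on the urea nitrogen. With nothing measured on the sulfonyl chain, the expected step in this assay is none beyond the scatter. Compound 4 is therefore estimated at 9500 nM, with a range from 4000 nM to 25000 nM. That estimate amounts to a 1.0-fold higher number from compound 1 to compound 4 (0.01 log units; within the scatter).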

Compound 4, half-maximal effective concentration: 9500 nM
For compound 4 middle estimate and measured number coincide at the digits printed; low and high end bracket the measured number.
By their numbers in this assay, from the lowest: compounds 1, 4 and 2 (each within the scatter of the next). At a limit, above all of these: compound 3.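

Within the data shown here, compound 1 and compound 4 differ only on the sulfonyl chain, whereas the earlier steps concerned only the aryl group on the urea nitrogen. In this assay, methanesulfonamido changing to (ethylsulfonyl)amino gives a 1.0-fold higher number from compound 1 to compound 4 (0.01 log units; within the scatter), so this added methyl on the saturated chain carbon bound to the sulfonyl sulfur leaves the number unchanged within the scatter. The data shown offer no explanation for this result.

Still open, going by these compounds, is whether a longer chain, such as propyl, or a chain ending in an amine or a carboxylic acid would behave the same way. On these data alone, it is also open whether ethyl would give a similar result with the 3-chlorophenyl group of compound 2.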